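This account rests on a few compounds, and the source may have more. Where it says the series, first, only, none or still open, it means among the compounds named here.

Compound 1 `Nc1ccc(SCC(=O)Nc2ccc3nc(NC(=O)c4ccc(C(F)(F)F)cc4)sc3c2)cc1` and compound 2 `O=C(CSc1ccc(Cl)cc1)Nc1ccc2nc(NC(=O)c3ccc(C(F)(F)F)cc3)sc2c1` share one core and differ in a single place. In a functional assay on U2OS cells (Homo sapiens) for antiproliferative activity, read by MTT assay, with a stated time of 72 h (a lower number here means a stronger inhibitor, a higher number a weaker inhibitor), compound 1 gives 1220 nM and compound 2 gives 2890 nM as a half-maximal inhibitory concentration. Compound 2 therefore holds the higher of the two numbers and is the weaker inhibitor of the pair. Within the data shown here, the only measured step, chloro in place of amino on an aromatic carbon, is a 2.4-fold higher number from compound 1 to compound 2 (0.37 log units; beyond the scatter) and so modest.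

Compound 3 `O=C(CSC1CCCCC1)Nc1ccc2nc(NC(=O)c3ccc(C(F)(F)F)cc3)sc2c1` is changed elsewhere: cyclohexyl in place of 4-chlorophenyl on a sulfur with cyclohexyl in place of 4-chlorophenyl on a sulfur. The whole aromatic ring leaves here, whereas the measured step only swapped one group on an aromatic carbon. Among the measured compounds shown here, no measured compound carries a non-aromatic ring on this sulfur, so that step bears only loosely on the new change. It offers a rough scale and no direction. No step beyond the scatter is therefore expected, and the estimated move is a 1.0-fold higher number from compound 2 to compound 3 (0.02 log units; within the scatter) in this assay but with wide uncertainty. For compound 3 the expected value is 3000 nM within an estimated range of 1200 nM to 7500 nM.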

Compound 3, half-maximal inhibitory concentration: 12300 nM
For compound 3 the middle estimate is 4.1-fold (0.61 log units) below the measured one; measured number outside the range, above it.
By their numbers in this assay, from the lowest: compound 1; then compound 2; then compound 3.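

The group on this sulfur is not interchangeable in this assay: the earlier step changed only a substituent on the aromatic ring, whereas replacing the ring itself, with cyclohexyl in place of 4-chlorophenyl, gives a 4.3-fold higher number from compound 2 to compound 3 (0.63 log units; beyond the scatter) and lies beyond the scatter. Set against the amino-bearing ring, the same cyclohexyl gives a 10-fold higher number from compound 1 to compound 3 (1.00 log units; beyond the scatter) and so spans the whole range of numbers seen here, with both aromatic rings on the sulfur holding lower numbers than the non-aromatic ring and no compound shown going against that order. No information is available here that would explain this difference.

The compounds shown do not separate the loss of the aromatic ring from the loss of its substituent, and an unsubstituted phenyl on the sulfur would be needed to tell these apart. They also leave open how a cyclohexyl ring carrying an amine, a piperidine ring or an open butyl chain in this place would read, so the comparison rests on a single non-aromatic group.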